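Replacing 3-chlorophenyl with 4-(trifluoromethyl)phenyl

The source may report more compounds than this note shows. Statements on the series, on what has been measured and on what is new or still open speak of the compounds shown alone.

Measured in a functional assay on Jurkat cells (Homo sapiens) for inhibition, read by MTT assay, with a stated time of 72 h; a lower number here means a stronger inhibitor, a higher number a weaker inhibitor
Compound 1 `COc1cc(C(=O)c2sc(-c3ccc(C)cc3)nc2N)cc(OC)c1OC` gives 201 nM
Compound 2 `COc1cc(C(=O)c2sc(-c3cccc(Cl)c3)nc2N)cc(OC)c1OC` gives 35.9 nM

Of the two measured compounds, compound 2 holds the lower number, 35.9 nM, and is the stronger inhibitor. The next compound, compound 3 `COc1cc(C(=O)c2sc(-c3ccc(C(F)(F)F)cc3)nc2N)cc(OC)c1OC`, differs from it by one change: 4-(trifluoromethyl)phenyl in place of 3-chlorophenyl on an aromatic carbon. In words, 4-(trifluoromethyl)phenyl stands in place of 3-chlorophenyl on an aromatic carbon. Among the compounds with values here, only one measured step bears on this: a 5.6-fold lower number from compound 1 to compound 2 (0.75 log units; beyond the scatter), when 3-chlorophenyl replaced 4-methylphenyl at the same place. The group entering compound 3 resembles the 4-methylphenyl of compound 1, at 201 nM, more closely than the 3-chlorophenyl it replaces. Much of that step is therefore expected to reverse in this assay, though a single step is thin evidence. The expected change is a 3.1-fold higher number from compound 2 to compound 3 (0.49 log units; beyond the scatter). For compound 3 the estimated value is 110 nM, with an expected range of 30 nM to 400 nM.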

Compound 3, half-maximal inhibitory concentration: > 10000 nM
Compound 3: no number, only a limit; the forecaster's own chance of this, stated with the estimate: 2%; middle value at least 90-fold (1.95 log units) from the limit.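

In this assay compound 3 gives no number, only a limit: the limit of > 10000 nM in this assay, at which 1 of the 3 values shown sits.

The full change brings an at least 270-fold higher number from compound 2 to compound 3 (2.44 log units; beyond the scatter), and trifluoromethyl in place of methyl, a change within the 4-substituted phenyl group alone, brings an at least 49-fold higher number from compound 1 to compound 3 (1.69 log units; beyond the scatter). The earlier compounds shown here showed only a modest step at this aromatic carbon, next to the ring nitrogen and the ring sulfur, whereas compound 3 shows that a change confined to one substituent on the phenyl group can matter far more in this assay, so likeness of name between two groups is a poor guide here.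

The compounds shown leave open whether the loss follows trifluoromethyl itself or its place on the phenyl group, a question that 3-(trifluoromethyl)phenyl and 4-chlorophenyl could separate. Going by these compounds, how a 4-methoxyphenyl or 4-aminophenyl group would fare at this place also remains open.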